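The source may hold more compounds than are shown below. What is called first, only, known or untested is meant among the compounds shown, and "the series" means these compounds.

In a functional assay on ECa-109 cells (Homo sapiens) for cytotoxicity, read by MTT assay, with a stated time of 48 h (on this read-out higher numbers stand for weaker inhibition and lower numbers for stronger inhibition), compound 1 `O=C1C(O)=C(C(c2cccc([N+](=O)[O-])c2)c2c[nH]c3ccccc23)C(=O)c2ccccc21` gives 36200 nM, the highest number among the three compounds measured. Compound 2 `O=C1C(O)=C(C(c2cccc([N+](=O)[O-])c2)c2c(-c3ccccc3)[nH]c3ccccc23)C(=O)c2ccccc21` gives 5830 nM, and compound 3 `COc1cc(C(C2=C(O)C(=O)c3ccccc3C2=O)c2c[nH]c3ccc(Br)cc23)cc(OC)c1OC` gives 13000 nM. Within the data shown here, the one single-point step measured so far is a 6.2-fold lower number from compound 1 to compound 2 (0.79 log units; beyond the scatter), which comes from adding phenyl to the core rather than from altering the group on the saturated chain carbon. Compound 3 differs from compound 1 in more than one place, so its value shows only that a different pairing of groups can give a lower number than compound 1.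

Compound 4 `O=C1C(O)=C(C(c2ccc(F)cc2)c2c[nH]c3ccccc23)C(=O)c2ccccc21` differs from compound 1 in one place: 4-fluorophenyl in place of 3-nitrophenyl on a saturated chain carbon bound to an aromatic carbon and a double-bonded ring carbon. Among the measured compounds shown here, no measured pair changes this part of the molecule, so the only guidance is that the swap keeps an aromatic ring of the same size in the same place while the counted donors and acceptors change as stated above. Without a measured step at this position, the expected change is small, at most near the edge of the scatter, with the direction uncertain. The estimate for compound 4 in this assay is therefore 25000 nM, between 8000 nM and 80000 nM, which means an expected step of a 1.4-fold lower number from compound 1 to compound 4 (0.16 log units; within the scatter).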

Compound 4, half-maximal inhibitory concentration: 28100 nM
Beside the measured number, compound 4's estimate is 1.1-fold (0.05 log units) below it; measured number inside the range.
By their numbers in this assay, from the lowest: compound 2; then compound 3; then compounds 4 and 1 (each within the scatter of the next).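

In this assay, putting 4-fluorophenyl in place of 3-nitrophenyl on a saturated chain carbon bound to an aromatic carbon and a double-bonded ring carbon gives a 1.3-fold lower number from compound 1 to compound 4 (0.11 log units; within the scatter), so this measurement does not separate the two groups. Among these compounds, this is the first measured change at this place, and it shows that the hydrogen-bond acceptors counted on 3-nitrophenyl can be absent, with nitrogen and oxygen giving way to a single fluorine, without a step beyond the scatter, whereas the phenyl change on the core gave a 6.2-fold lower number from compound 1 to compound 2 (0.79 log units; beyond the scatter). No other measurement bears on this result, so nothing here can say what lies behind the small step.

On these data alone, only these two substituted phenyl rings can be compared at this place, so it remains open whether a group such as cyclohexyl, a plain methyl or a phenyl carrying a carboxylic acid would leave the number just as little changed. As far as these compounds go, it is also open whether the phenyl on the core would lower the number by a similar step when 4-fluorophenyl sits on the chain carbon in place of 3-nitrophenyl.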